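The source may report more compounds than this note shows. Statements on the series, on what has been measured and on what is new or still open speak of the compounds shown alone.

Working notes on the series. The shared core is a cyclic diamino system bearing an oxygen-linked three-carbon chain to an aryl ether; compound 1 `NC1=NC2(CCOCC2)N(OCCCOc2cccc(Cl)c2Cl)C(N)=N1` carries the oxygen-containing variant of the core and a 2,3-dichlorophenyl ether, compound 2 `NC1=NC2(CCSCC2)N(OCCCOc2ccc(Br)cc2)C(N)=N1` the sulfur-containing variant with a 4-bromophenyl ether, and compound 3 `NC1=NC2(CCOCC2)N(OCCCOc2ccccc2)C(N)=N1` the oxygen-containing variant with an unsubstituted phenyl ether. In an assay on isolated protein for inhibition of Dihydrofolate reductase (Homo sapiens), read by spectrophotometry, using NADPH, with stated times of 5 s and 6 min, tested at 50 uM (on this read-out higher numbers stand for a stronger effect at the one concentration tested and lower numbers for a weaker effect), compound 1 gives 89.8%. In this assay compound 2 gives "not determined" (no result reported), and compound 3 gives "not determined" (no result reported) there, so compound 2 stands without a single value against which the next change can be weighed.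

Compound 4 `NC1=NC2(CCSCC2)N(OCCCOc2ccc(Cl)c(Cl)c2)C(N)=N1` is the next member. Relative to compound 2 the change is 3,4-dichlorophenyl in place of 4-bromophenyl on an oxygen on a saturated carbon. Within the data shown here, no measured step is available, so the size of the step in this assay cannot be drawn from data; the only anchor is that compound 1, also a dichlorophenyl ether, gives 89.8%, and on that basis compound 4 is expected to sit at a similar high level rather than to move in either direction beyond the scatter. Compound 4 is estimated to give about 85% in this assay, with a plausible range from 65% to 98%.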

Compound 4, a percentage reported as inhibition, at one concentration (the size of the read-out at that concentration, not a potency): 89.8%
Compound 4: the middle estimate sits 4.8 percentage points below what was measured; measured number inside the range.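

In this assay, among these compounds, compound 2 has no single number, so no step to compound 4 can be read. The compounds shown leave open how the read-out responds to 3,4-dichlorophenyl in place of 4-bromophenyl alone, or to the sulfur-containing core variant against the oxygen-containing one. No evidence bears on the result of compound 4.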